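Replacing the Aryl Group of a Thiourea with a Butyl Chain

The source may report more compounds than this note shows. Statements on the series, on what has been measured and on what is new or still open speak of the compounds shown alone.

Measured so far:
- Compound 1 `COc1cc2c(cc1OC)C(=O)C(CC1CCN(C(=S)Nc3cccc(C)c3)CC1)C2`: 300 mg/kg
- Compound 2 `COc1cc2c(cc1OC)C(=O)C(CC1CCN(C(=S)Nc3ccc(C)cc3)CC1)C2`: 30 mg/kg
- Compound 3 `COc1cc2c(cc1OC)C(=O)C(CC1CCN(C(=S)Nc3ccccc3Cl)CC1)C2`: 100 mg/kg

These values come from a functional assay on the whole organism (strain Swiss albino) with Mus musculus as the target, in the maximal electroshock model, with a stated time of 0.5 h; on this read-out higher numbers stand for an effect only at larger amounts of compound and lower numbers for an effect already at smaller amounts. Compound 3 holds the second highest of the three numbers, with a 3.0-fold lower number from compound 1 to compound 3 (0.48 log units; beyond the scatter) and a 3.3-fold higher number from compound 2 to compound 3 (0.52 log units; beyond the scatter) placing it between its two neighbours. Compound 4 `CCCCNC(=S)N1CCC(CC2Cc3cc(OC)c(OC)cc3C2=O)CC1` differs from compound 3 in one place: butyl in place of 2-chlorophenyl on an amide-type nitrogen. Within the data shown here, none of the measured steps swaps the aromatic ring itself for a chain; they only move or exchange substituents on that ring, and all three of those steps were modest. Without a direct precedent, the expected step of no change at the digits printed from compound 3 to compound 4 (within the scatter) is none beyond the scatter, with wide uncertainty. Compound 4 is therefore estimated at 100 mg/kg, ranging from 30 mg/kg to 300 mg/kg.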

Compound 4, minimum effective dose: 100 mg/kg
Beside the measured number, compound 4's estimate shows no gap at the digits printed; the range from low to high includes it.
By their numbers in this assay, from the lowest: compound 2; then compounds 3 and 4 (each within the scatter of the next); then compound 1.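

Swapping the aromatic ring on this amide-type nitrogen for an open chain is tolerated here: replacing 2-chlorophenyl with butyl gives no change at the digits printed from compound 3 to compound 4 (within the scatter) and shows that, in this pair, a ring at this place is not needed. The butyl chain does not simply outperform or fall short of the aryl groups, with a 3.3-fold higher number from compound 2 to compound 4 (0.52 log units; beyond the scatter) but also a 3.0-fold lower number from compound 1 to compound 4 (0.48 log units; beyond the scatter). Nothing measured here accounts for these results. As far as these compounds go, whether a shorter chain such as ethyl, a branched group such as tert-butyl, or a butyl chain ending in an amine would behave the same way remains open.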